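Replacing the butyl of compound 3 with a fluorophenylamino group

The source may hold more compounds than are shown below. What is called first, only, known or untested is meant among the compounds shown, and "the series" means these compounds.

Among the measured compounds shown here, compound 3 `CCCCC(=O)Nc1ccc2[nH]cc(C3CCN(C)CC3)c2n1` sits at the high end of the three numbers measured so far in an assay for binding affinity to 5-hydroxytryptamine receptor 1F (Homo sapiens), read by radioligand binding (a higher number here means a weaker inhibitor, a lower number a stronger inhibitor), where compound 3 gives 14 nM. Compound 1 `CCCCCC(=O)Nc1ccc2[nH]cc(C3CCN(C)CC3)c2n1` gives 13 nM and compound 2 `CN1CCC(c2c[nH]c3ccc(NC(=O)c4cccs4)nc23)CC1` gives 7.1 nM; the steps of a 1.1-fold higher number from compound 1 to compound 3 (0.03 log units; within the scatter) and a 2.0-fold higher number from compound 2 to compound 3 (0.29 log units; within the scatter) both stay inside the scatter, as does a 1.8-fold lower number from compound 1 to compound 2 (0.26 log units; within the scatter). Compound 4 `CN1CCC(c2c[nH]c3ccc(NC(=O)Nc4ccc(F)cc4)nc23)CC1` differs from compound 3 only at the carbonyl carbon: (4-fluorophenyl)amino in place of butyl on a carbonyl carbon. The two measured exchanges at that same carbonyl carbon, from pentyl to thiophen-2-yl and from thiophen-2-yl to butyl, moved the number little, so no step beyond the scatter is expected here, a 1.4-fold lower number from compound 3 to compound 4 (0.15 log units; within the scatter). Compound 4 is therefore estimated at 10 nM, within a range from 3 nM to 35 nM.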

Compound 4, inhibition constant: 11 nM
Compound 4: the middle estimate sits 1.1-fold (0.04 log units) below what was measured, within the range that was stated.
By their numbers in this assay, from the lowest: compounds 2, 4, 1 and 3 (each within the scatter of the next).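

At the carbonyl carbon, (4-fluorophenyl)amino brings in a six-membered aromatic ring and a hydrogen-bond donor, yet in this assay every new step stays within the scatter: (a 1.3-fold lower number from compound 3 to compound 4 (0.10 log units; within the scatter)), (a 1.5-fold higher number from compound 2 to compound 4 (0.19 log units; within the scatter)) and (a 1.2-fold lower number from compound 1 to compound 4 (0.07 log units; within the scatter)). This position, already seen carrying pentyl, butyl and thiophen-2-yl, thus also takes a group joined through nitrogen without a step beyond the scatter among these four compounds. No evidence is available to account for this result. From the compounds shown here alone, what a carboxylic acid or a dimethylamino group on this carbonyl carbon would do to the number stays open, as does the part played by the fluorine in (4-fluorophenyl)amino.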